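The compounds below may be only part of what the source reports. "The series", "measured", "known", "first", "only" and "open" are said of these compounds alone.

Compound 1 `CC1(C)CC(=O)c2cc([N+](=O)[O-])c(NC3CC=C(c4ccc(F)cc4)CC3)nc2C1` gives 12000 nM in a functional assay for antagonist activity at metabotropic glutamate receptor 1 (Rattus norvegicus), read by FLIPR; on this read-out lower numbers stand for stronger inhibition and higher numbers for weaker inhibition. Compound 2 `CC1(C)CC(=O)c2cc(Cl)c(NC3CCCC3)nc2C1` gives 7900 nM in this assay.

Of the compounds shown here, two have been measured so far, and both carry the same shared core. Compound 2 has the lower of the two numbers, but its gap to compound 1 lies within the usual scatter of repeated measurements, so the two cannot be told apart on these data. Both sit in a weak range of inhibition.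

The next compound, compound 3 `CC1(C)CC(=O)c2cc(-c3nn[nH]n3)c(NC3CCCC3)nc2C1`, has not yet been measured. It differs from compound 2 in one place: 2H-tetrazol-5-yl in place of chloro on an aromatic carbon. For the measured compounds named here, no measured pair of compounds shows this particular exchange, so there is no step on record from which its effect can be read off directly. With only this to go on, the expected step from compound 2 to compound 3 is a 1.9-fold higher number from compound 2 to compound 3 (0.28 log units; within the scatter), a modest move toward weaker inhibition that may well stay within the scatter. Compound 3 is expected to give about 15000 nM, with a likely range from 5000 nM to 50000 nM.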

Compound 3, half-maximal inhibitory concentration: 13000 nM
Estimate against measurement, compound 3: 1.2-fold (0.06 log units) above; measured number inside the range.
By their numbers in this assay, from the lowest: compounds 2, 1 and 3 (each within the scatter of the next).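

In this assay, putting 2H-tetrazol-5-yl in place of chloro gives a 1.6-fold higher number from compound 2 to compound 3 (0.22 log units; within the scatter), so compound 2 and compound 3 cannot be told apart on this read-out. At this aromatic carbon, ortho to the cyclopentylamino group, a single chlorine atom and a group of 5 heavy atoms, with its own five-membered aromatic ring and a hydrogen-bond donor, thus give numbers that lie within the scatter of each other, and the large change in the group brings no readable change in inhibition. No separate measurement is available to explain this result. Going by these compounds, whether any other group at this position, such as a carboxylic acid, a primary amine or a nitrile, would shift the number beyond the scatter in either direction remains open. Compound 1 carries a nitro group at this position, but it also differs from compound 2 in the group on the amino nitrogen, so the effect of the nitro group alone cannot be read from these compounds.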